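The source may report more compounds than this note shows. Statements on the series, on what has been measured and on what is new or still open speak of the compounds shown alone.

Compound 1, drawn as `NS(=O)(=O)c1cccc(/N=C2\NC(=O)/C(=C3/C(=O)Nc4ccccc43)S2)c1`, carries a sulfonamide-bearing aromatic ring on one side of the shared core. In a functional assay on Caco-2 cells (Homo sapiens) for antiproliferative activity, read by MTT assay (a higher number here means a weaker inhibitor, a lower number a stronger inhibitor), compound 1 gives 12100 nM. Compound 2, drawn as `NS(=O)(=O)c1ccc(/N=C2\NC(=O)/C(=C3/C(=O)N(Cc4ccccc4)c4ccccc43)S2)cc1`, moves the sulfonamide to another position on that ring and adds a benzyl group on the amide nitrogen of the core. In this assay compound 2 reaches only a limit of the measurement, > 200000 nM, and not a number. Compound 2 thus stands at the limit of > 200000 nM in this assay, at which 1 of the 2 values shown sits, so the whole range of stronger inhibition lies on the other side of it. Compound 3, drawn as `NS(=O)(=O)c1ccc(/N=C2\NC(=O)/C(=C3/C(=O)N(Cc4ccccc4)c4ccc(Cl)cc43)S2)cc1`, differs from compound 2 by chloro in place of hydrogen on an aromatic carbon. No measured step of this kind exists among these compounds. The expected change is a step that the limit leaves unreadable from compound 2 to compound 3, none beyond the usual scatter. Compound 3 is therefore estimated to give 250000 nM, with a range from 70000 nM to 800000 nM.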

Compound 3, half-maximal inhibitory concentration: 13700 nM
For compound 3 the middle estimate is 18-fold (1.26 log units) above the measured one; measured number below the stated range.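

Within the data shown here, no earlier compound showed what a change on this aromatic carbon does. In this assay, chloro in place of hydrogen gives an at least 14-fold lower number from compound 2 to compound 3 (1.16 log units; beyond the scatter), so one added heavy atom at this position is enough to bring a compound from the limit of the measurement to a measured number. Only the smallest possible size of this step is known, and the true gap could be wider: the limit of > 200000 nM in this assay, at which 1 of the 3 values shown sits.

The compounds shown leave open whether chloro is special here, since fluoro, methoxy or an amine on the same carbon would show whether other groups give a similar step. They also leave open whether chloro gives a step of this size with the sulfonamide placed as in compound 1, or with a methyl group instead of the benzyl group on the amide nitrogen.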